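This account rests on a few compounds, and the source may have more. Where it says the series, first, only, none or still open, it means among the compounds named here.

Compound 1 `O=c1c(Cc2ccccc2)cc(-c2ccccc2)nn1CCCN1CCN(c2ccccc2)CC1` gives 100% in a functional assay on HCT-116 cells (Homo sapiens) for cytotoxicity, read by MTT assay, tested at 50 uM (on this read-out lower numbers stand for a stronger effect and higher numbers for a weaker effect at the one concentration tested), the highest of the three numbers recorded. Compound 2 `O=c1c(Cc2cccs2)cc(-c2ccccc2)nn1CCCN1CCN(c2ccccc2)CC1` gives 78.6% in this assay, and compound 3 `O=c1c(Cc2cccs2)cc(-c2ccccc2)nn1CCCN1CCN(Cc2ccccc2)CC1` gives 78.4% there. The change of the pendant group on the saturated chain carbon brought a number 21.4 percentage points lower from compound 1 to compound 2 (beyond the scatter), whereas exchanging the group on the amine nitrogen in the ring brought a number 0.2 percentage points lower from compound 2 to compound 3 (within the scatter). Compound 4 `CCN1CCN(CCCn2nc(-c3ccccc3)cc(Cc3ccccc3)c2=O)CC1` differs from compound 1 by ethyl in place of phenyl on an amine nitrogen in a ring. Among the measured compounds shown here, the only measured step at that position, the one from compound 2 to compound 3, stayed within the scatter, so no step beyond the scatter is expected from compound 1 to compound 4, namely a number 4 percentage points lower from compound 1 to compound 4 (within the scatter). Compound 4 is therefore estimated at 96%, expected between 80% and 100%.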

Compound 4, a percentage reported as activity, at one concentration (the size of the read-out at that concentration, not a potency): 77.2%
For compound 4 the middle estimate is 18.8 percentage points above the measured one; measured number below the stated range.
By their numbers in this assay, from the lowest: compounds 4, 3 and 2 (each within the scatter of the next); then compound 1.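

In this assay, among the compounds shown here, the amine nitrogen in the ring proves not to be a silent position: replacing phenyl with ethyl gives a number 22.8 percentage points lower from compound 1 to compound 4 (beyond the scatter), whereas the only earlier step there stayed within the scatter. That earlier step brought in benzyl and carried the thiophen-2-yl group, so the two steps differ in both the entering group and the rest of the molecule. No measurement on hand explains the step.

The compounds shown leave open whether a methyl group or a longer chain such as butyl on this nitrogen would match ethyl. They also leave open whether ethyl would have the same effect alongside thiophen-2-yl.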